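Oxadiazole in Place of the Methoxymethyl Sulfoxide Chain

This account rests on a few compounds, and the source may have more. Where it says the series, first, only, none or still open, it means among the compounds named here.

In an assay on isolated protein for inhibition of Norepinephrine transporter (Rattus norvegicus), read by radioligand binding (on this read-out higher numbers stand for weaker inhibition and lower numbers for stronger inhibition), compound 1 `COC(=O)C[S+]([O-])CC1CN(C)CCC1c1ccc(Cl)cc1` gives 53 nM, while compound 2 `COCC[S+]([O-])CC1CN(C)CCC1c1ccc(Cl)cc1` gives 25 nM, the lowest of the two numbers, with the step of a 2.1-fold lower number from compound 1 to compound 2 (0.33 log units; beyond the scatter) separating them. Compound 3 `Cc1noc(C[S+]([O-])CC2CN(C)CCC2c2ccc(Cl)cc2)n1` carries 3-methyl-1,2,4-oxadiazol-5-yl in place of methoxymethyl on a saturated chain carbon bound to a sulfur. Among the measured compounds shown here, only that one step bears on the change, and it was modest, so an aromatic ring entering at the same place is read as a step of similar or somewhat smaller size, in either direction. For compound 3 the estimated step is a 1.6-fold higher number from compound 2 to compound 3 (0.20 log units; within the scatter), and its value in this assay is expected near 40 nM, likely between 15 nM and 120 nM.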

Compound 3, inhibition constant: 218 nM
Beside the measured number, compound 3's estimate is 5.5-fold (0.74 log units) below it, outside the stated range (above it).
By their numbers in this assay, from the lowest: compound 2; then compound 1; then compound 3.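

At the place on a saturated chain carbon bound to a sulfur, the change to an aromatic ring moves the number in this assay much further than the earlier change of chain did, with an 8.7-fold higher number from compound 2 to compound 3 (0.94 log units; beyond the scatter) and a 4.1-fold higher number from compound 1 to compound 3 (0.61 log units; beyond the scatter). Among these compounds, the 3-methyl-1,2,4-oxadiazol-5-yl group thus gives weaker inhibition than either methoxymethyl or methoxycarbonyl. Nothing available explains this shift. From the compounds shown here alone, it remains open whether the weakening belongs to aromatic rings in general or to this ring, and how an amide or a carboxylic acid would read at this place.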